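Defining one stereocentre in a fluorinated cytosine dioxolane

The source may hold more compounds than are shown below. What is called first, only, known or untested is meant among the compounds shown, and "the series" means these compounds.

compound 1 `C[C@]1(CO)OC[C@@H](n2ccc(N)nc2=O)O1` gives 30000 nM in a functional assay on CCRF-CEM cells (Homo sapiens) for inhibition; a higher number here means a weaker inhibitor, a lower number a stronger inhibitor
compound 2 `CC1(CO)OCC(n2ccc(N)nc2=O)O1` gives 30000 nM
compound 3 `CC1(CO)OCC(n2cc(F)c(N)nc2=O)O1` gives only a limit, > 100000 nM

Compound 3 stands at the weak end of what was measured: its result is a limit of the assay and not a number, namely (the limit of > 100000 nM in this assay, at which 1 of the 3 values shown sits). Compound 4 `CC1(CO)OC[C@@H](n2cc(F)c(N)nc2=O)O1` has the same atoms and bonds and differs only in how one centre is drawn: the two compounds have the same atoms and bonds; at least one stereo element is drawn with a configuration in one of them and without one in the other: 1 of 2 stereo elements differ; a stereocentre at a saturated ring carbon is drawn without a configuration in compound 3 and S in compound 4. Going by the values given here, the one measured step of this kind, no change at the digits printed from compound 1 to compound 2 (within the scatter), stayed within the scatter, the pair being the one described by the fact that one of compounds 1 and 2 is drawn with a defined configuration and the other without, at the place where they differ. The fluoro step an at least 3.3-fold higher number from compound 2 to compound 3 (0.52 log units; beyond the scatter) does not bear on this change, as compound 3 and compound 4 both carry the fluorine. Compound 4 is therefore expected to show a step that the limit leaves unreadable from compound 3 to compound 4, most likely again only as a limit. The estimate for compound 4 is 150000 nM, between 50000 nM and 500000 nM.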

Compound 4, half-maximal inhibitory concentration: > 100000 nM
Compound 4: no number, only a limit; the forecaster's own chance of this, stated with the estimate: 80%; the middle value lies beyond the limit too.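

Going by these compounds alone, compound 3 and compound 4 each give only a limit of the assay in this assay, and no step between them can be read. The compounds shown leave open whether defining this stereocentre alters inhibition among the fluorinated compounds.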